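From 4-(trifluoromethyl)phenyl to 4-fluorophenyl in compound 3

The compounds below may be only part of what the source reports. "The series", "measured", "known", "first", "only" and "open" are said of these compounds alone.

Measured so far in a functional assay on SMMC-7721 cells (Homo sapiens) for cytotoxicity, read by MTT assay, with a stated time of 24 h; on this read-out lower numbers stand for stronger inhibition and higher numbers for weaker inhibition
Compound 1 `CN1C/C(=C\c2ccncc2)C(=O)/C(=C/c2ccccc2F)C1` gives 7000 nM
Compound 2 `O=C1/C(=C/c2ccncc2)CN(S(=O)(=O)c2ccc(C(F)(F)F)cc2)C/C1=C\c1ccccc1F` gives 11100 nM

Only these two numbers are available, and they do not separate the compounds. Compound 2 (at 11100 nM) and compound 1 (at 7000 nM) lie within the usual scatter of each other, so compound 2 stands level with compound 1.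

The next compound to be tested is compound 3 `O=C1/C(=C/c2ccncc2)CN(S(=O)(=O)c2ccc(F)cc2)C/C1=C\c1ccccc1F`, which differs from compound 2 in one place. It carries fluoro in place of trifluoromethyl on an aromatic carbon, para to a large group (fluoro in place of trifluoromethyl on an aromatic carbon).

Among the compounds with values here, no measured pair shows this change, or any other single change, so the data offer no direct step to go by. Within the data shown here, the only guide is the narrow spread of the two known values. On that basis, no step beyond the scatter is expected in this assay, and neither direction is favoured.

The estimated change is a 1.2-fold lower number from compound 2 to compound 3 (0.09 log units; within the scatter), which is expected to remain within the scatter. For compound 3 the expected value is 9000 nM, with an estimated range from 4000 nM to 20000 nM.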

Compound 3, half-maximal inhibitory concentration: > 20000 nM
Compound 3 was reported as a limit (the forecaster's own chance of this, stated with the estimate: 3%); middle value at least 2.2-fold (0.34 log units) away from the limit.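

In this assay compound 3 gives > 20000 nM, which is a limit of the assay and not a number. Fluoro in place of trifluoromethyl on the aromatic carbon, para to a large group, brings an at least 1.8-fold higher number from compound 2 to compound 3 (0.25 log units; that floor lies within the scatter), so this floor alone does not establish a real difference, though it leaves room for one that the earlier values could not have revealed. (4-Fluorophenyl)sulfonyl in place of methyl on the amine nitrogen in the ring brings an at least 2.8-fold higher number from compound 1 to compound 3 (0.45 log units; beyond the scatter), the only step here printed as beyond the scatter, and both steps remain floors rather than measured sizes because compound 3 is reported as a limit: the limit of > 20000 nM in this assay, at which 1 of the 3 values shown sits.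

As far as these compounds go, how far compound 3 truly lies from compound 2 stays open, and so does whether the change from trifluoromethyl to fluoro matters at all in this assay. Also open, from the compounds shown here alone, is how other groups on that aromatic carbon, such as a methoxy group, an amine or a carboxylic acid, would read in this assay.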